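The source may report more compounds than this note shows. Statements on the series, on what has been measured and on what is new or still open speak of the compounds shown alone.

The measured compounds, with their readings in an in vitro functional assay on Ltk cells for inhibition of metabotropic glutamate receptor 5 (Homo sapiens), read by calcium flux; a higher number here means a weaker inhibitor, a lower number a stronger inhibitor:

Compound 1 `O=C1c2ccccc2C(=O)N1C1C=C(C#Cc2ccccn2)CCC1` gives 27 nM.
Compound 2 `C(#Cc1ccccn1)C1=CCNCC1` gives 580 nM.
Compound 3 `Cc1cccc(S(=O)(=O)N2CC=C(C#Cc3ccccn3)CC2)c1` gives 8.2 nM.

In this assay compound 3 stands lowest of the three numbers. Its nearest neighbour is compound 1, whose number is higher by a margin beyond the usual scatter, and the furthest is compound 2, whose number is higher still, far beyond the scatter. The three share the pyridine-alkyne arm on a six-membered ring, and differ in what sits on the ring nitrogen or carbon of that core.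

Compound 4 `Cc1ccc(S(=O)(=O)N2CC=C(C#Cc3ccccn3)CC2)cc1` has not been measured. It differs from compound 3 in one place: 4-methylphenyl in place of 3-methylphenyl on a sulfonyl sulfur. The two compounds contain the same atoms joined differently, so only the position of the methyl on the phenyl moves.

For the measured compounds named here, no measured pair in this set shows what such a shift does. With nothing to point in either direction, the expected change from compound 3 to compound 4 is none beyond the scatter, estimated as a 1.1-fold higher number from compound 3 to compound 4 (0.04 log units; within the scatter). In this assay compound 4 is therefore expected to give about 9 nM, with a likely range from 3.5 nM to 25 nM.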

Compound 4, half-maximal inhibitory concentration: 7.9 nM
Compound 4: the middle estimate sits 1.1-fold (0.06 log units) above what was measured, and the stated range covers the measured number.
By their numbers in this assay, from the lowest: compounds 4 and 3 (each within the scatter of the next); then compound 1; then compound 2.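

In this assay, 4-methylphenyl in place of 3-methylphenyl on a sulfonyl sulfur gives a 1.0-fold lower number from compound 3 to compound 4 (0.02 log units; within the scatter), and this step lies within the scatter. For the compounds shown here, it is the first step in the set that changes one place only, and it shows that, for this pair, moving the methyl around the phenyl leaves the reading where it was, with the sulfonamide nitrogen in a ring and the pyridine-alkyne arm unchanged. Nothing measured on these compounds bears on why the two read alike.

On these data alone, two placements of a single methyl say little about the phenyl as a whole, so it remains open whether a plain phenyl, or one carrying a chlorine, a methoxy group or a carboxylic acid in place of the methyl, would read the same. Also open is what the sulfonyl link itself contributes, since the compounds shown leave untested whether an amide or a simple alkyl chain on the ring nitrogen of the shared core would hold the reading of compound 3 and compound 4.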